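This account rests on a few compounds, and the source may have more. Where it says the series, first, only, none or still open, it means among the compounds named here.

Among the measured compounds shown here, in a functional assay on CFPAC-1 cells (Homo sapiens) for antiproliferative activity, read by MTT assay, with a stated time of 72 h (on this read-out higher numbers stand for weaker inhibition and lower numbers for stronger inhibition), compound 1 `CCCCc1cn(C[C@H](O)[C@H]2OC(=O)C(OCc3ccccc3)=C2OCc2ccccc2)nn1` gives 73200 nM, the only actual number among the measured compounds. Compound 2 `CC(C)(C)OC(=O)N1CCN(C(=S)SCc2cn(C[C@H](O)[C@H]3OC(=O)C(OCc4ccccc4)=C3OCc3ccccc3)nn2)CC1` reads > 100000 nM, which is a limit of the assay and not a number. Compound 3 `O=C1O/C(=C\Cn2cc(-c3cc(C(F)(F)F)cc(C(F)(F)F)c3)nn2)C(OCc2ccccc2)=C1OCc1ccccc1` reads > 100000 nM, which is likewise a limit. The measured set is therefore dominated by the limit of > 100000 nM in this assay, at which 2 of the 3 values shown sit. Compound 4 `CC(C)(C)c1cn(C[C@H](O)[C@H]2OC(=O)C(OCc3ccccc3)=C2OCc2ccccc2)nn1` carries tert-butyl in place of the butyl of compound 1, on an aromatic carbon of a five-membered aromatic ring with 3 nitrogen (tert-butyl in place of butyl on an aromatic carbon). For the measured compounds named here, no measured pair shows the effect of this swap. The expected size of a 1.1-fold higher number from compound 1 to compound 4 (0.04 log units; within the scatter) is none beyond the usual scatter of this assay, with no firm direction. Compound 4 is estimated at 80000 nM, with an expected range from 35000 nM to 140000 nM.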

Compound 4, half-maximal inhibitory concentration: 54900 nM
The estimate for compound 4 lay 1.5-fold (0.16 log units) above the measured number, within the range that was stated.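

In this assay the first readable step is a 1.3-fold lower number from compound 1 to compound 4 (0.12 log units; within the scatter), with tert-butyl in place of butyl on an aromatic carbon. At this position, then, the branched group and the straight chain cannot be told apart on this read-out. Compound 4 also adds a second actual number to a set still marked by a limit: the limit of > 100000 nM in this assay, at which 2 of the 4 values shown sit.

The compounds shown leave open whether an amine, a carboxylic acid or a longer chain on this aromatic carbon would move the number beyond the scatter, and in which direction.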